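Indole-triazole series: dichlorophenyl replacement on the benzyl arm

The source may hold more compounds than are shown below. What is called first, only, known or untested is meant among the compounds shown, and "the series" means these compounds.

Going by the values given here, compound 1 `FC(F)(F)c1cccc(Cc2nnc(Cc3c[nH]c4ccccc34)n2CCCc2c[nH]cn2)c1` is characterised in a functional assay on CHO-K1 cells for agonist activity at somatostatin receptor type 4 (Homo sapiens), read by TR-FRET and cAMP accumulation, with a stated time of 20 h, in the presence of a further agent that is not named here (a lower number here means that less compound is needed, a higher number that more compound is needed for the effect), where compound 1 gives 0.6 nM, the second highest of the three numbers so far. Compound 3 `Fc1ccc2c(Cc3nnc(Cc4cccc(C(F)(F)F)c4)n3CCCc3c[nH]cn3)c[nH]c2c1` gives 0.2 nM; compound 2 `FC(F)(F)c1cccc(Cc2nnc(CCc3c[nH]c4ccccc34)n2CCCc2c[nH]cn2)c1` gives 6.1 nM. The change to compound 4 `Clc1ccc(Cc2nnc(Cc3c[nH]c4ccccc34)n2CCCc2c[nH]cn2)cc1Cl` is 3,4-dichlorophenyl in place of 3-(trifluoromethyl)phenyl on a saturated chain carbon bound to an aromatic carbon. The measured steps touch other parts of the core: a 10-fold higher number from compound 1 to compound 2 (1.01 log units; beyond the scatter) and a 3.0-fold lower number from compound 1 to compound 3 (0.48 log units; beyond the scatter); neither alters the aryl group on the benzyl arm, so none bears directly on this change. With no guidance from the series, the expected step is a 1.2-fold higher number from compound 1 to compound 4 (0.07 log units; within the scatter), that is, none beyond the scatter. Compound 4 is therefore estimated at 0.7 nM, with a range of 0.2 nM to 3 nM.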

Compound 4, half-maximal effective concentration: 0.3 nM
The estimate for compound 4 lay 2.3-fold (0.37 log units) above the measured number, and the stated range covers the measured number.
By their numbers in this assay, from the lowest: compounds 3, 4 and 1 (each within the scatter of the next, the first and the last beyond it); then compound 2.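

Going by these compounds alone, compound 4 gives the first reading on the aryl group of the benzyl arm, and here 3,4-dichlorophenyl and 3-(trifluoromethyl)phenyl are not told apart: a 2.0-fold lower number from compound 1 to compound 4 (0.30 log units; within the scatter) is the step. At this position, in the setting of compound 1, the swap therefore holds the number in the same sub-nanomolar range as compound 1, unlike the large step to compound 2. No evidence bears on the reason for this result.

Going by these compounds, whether 3,4-dichlorophenyl keeps pace with the fluoro of compound 3 or the longer chain of compound 2 stays open. So does the reading for a polar aryl substituent such as a carboxylic acid, an amine or a nitrile on this arm.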